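Lengthening a chain on two related pyrazolone-type cores

A few compounds are considered here, and "the series" means these few. Any claim that something is new, unique, unknown or untested is made for them only; others in the source may bear on it.

Compound 1 `CCC(=O)c1c(C)nn(CCCN2CCN(c3ccc(C)cc3)CC2)c(=O)c1N` gives 40% in a functional assay on the whole organism (Abdomen, strain Swiss) for inhibition, with Mus musculus as the target, with stated times of 30 min, 10 min and 5 min, at a dose of 20 mg/kg by the oral route; a higher number here means a stronger effect of the compound at the dose given, a lower number a weaker effect. Compound 2 `CCCC(=O)c1c(C)nn(CCCN2CCN(c3ccc(C)cc3)CC2)c(=O)c1N` gives 25%, so the change methyl in place of hydrogen on a saturated chain carbon, two bonds along the chain from a carbonyl carbon made the step of a number 15 percentage points lower from compound 1 to compound 2 (beyond the scatter). Compound 3 `C=Cc1c(CCC)nn(CCCN2CCN(c3ccc(C)cc3)CC2)c(=O)c1N` carries a core whose difference from the core of compound 1 is not broken down here, and compound 3 gives 7%. Compound 4 `C=Cc1c(CCCC)nn(CCCN2CCN(c3ccc(C)cc3)CC2)c(=O)c1N` is not yet measured; it differs from compound 3 by methyl in place of hydrogen on a saturated chain carbon, three bonds along the chain from an aromatic carbon, the same kind of change as from compound 1 to compound 2, though the added methyl sits three bonds from an aromatic carbon rather than two bonds from a carbonyl carbon. Because a number 15 percentage points lower from compound 1 to compound 2 (beyond the scatter) was a modest fall and compound 3 starts low, the expected step is a number 2 percentage points lower from compound 3 to compound 4 (within the scatter). Compound 4 is therefore estimated at 5%, within 0% to 20%.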

Compound 4, a percentage reported as inhibition, in the whole organism at one dose (the size of the read-out at that dose, not a potency): 41%
The estimate for compound 4 lay 36 percentage points below the measured number; measured number above the stated range.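

In this assay, adding this methyl gives a number 34 percentage points higher from compound 3 to compound 4 (beyond the scatter), so the change does not carry over from the core of compound 1 to the core of compound 3 with the same direction or size: the same change on two cores in this assay, a number 15 percentage points lower (beyond the scatter) from compound 1 to compound 2 and a number 34 percentage points higher (beyond the scatter) from compound 3 to compound 4, 49 percentage points apart, beyond the scatter of two such steps

The comparison shows that the result of this change in one core cannot be used to predict its result in the other. Among the compounds shown here, it does not show why the two steps differ, since the cores differ and the added methyl also sits in a different place, three bonds along the chain from an aromatic carbon rather than two bonds from a carbonyl carbon, and each core provides only one step.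

The compounds shown leave open how a pentyl chain or a carboxylic acid in place of the butyl chain of compound 4 would behave. They also leave open whether a longer chain would raise or lower the number on either core.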